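The source may report more compounds than this note shows. Statements on the series, on what has been measured and on what is new or still open speak of the compounds shown alone.

Measured so far in a functional assay on U-87MG ATCC cells (Homo sapiens) for cytotoxicity, read by MTT assay, with a stated time of 72 h; on this read-out higher numbers stand for weaker inhibition and lower numbers for stronger inhibition:
- Compound 1 `CN(C)CCn1cnnc1-c1cc(Oc2ccc(NC(=O)N/N=C/c3c(Cl)cccc3Cl)cc2F)ccn1`: > 100000 nM, a limit of the assay and not a number
- Compound 2 `COc1ccc(OC)c(/C=N/NC(=O)Nc2ccc(Oc3ccnc(-c4nncn4CCN(C)C)c3)c(F)c2)c1`: 6400 nM
- Compound 3 `COc1ccc(/C=N/NC(=O)Nc2ccc(Oc3ccnc(-c4nncn4CCN(C)C)c3)c(F)c2)c(OC)c1`: 12600 nM

Compound 3 stands level with compound 2 within the usual scatter, as a 2.0-fold higher number from compound 2 to compound 3 (0.29 log units; within the scatter) shows, so moving from 2,5-dimethoxyphenyl to 2,4-dimethoxyphenyl leaves no clear mark on the number. Exchanging the 2,6-dichlorophenyl of compound 1 had a much clearer effect: an at least 15-fold lower number from compound 1 to compound 2 (1.19 log units; beyond the scatter) and an at least 7.9-fold lower number from compound 1 to compound 3 (0.89 log units; beyond the scatter). This group can therefore matter a great deal in this assay.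

Compound 4 `CN(C)CCn1cnnc1-c1cc(Oc2ccc(NC(=O)N/N=C/c3ccccc3)cc2F)ccn1` has phenyl in place of 2,4-dimethoxyphenyl on a carbon with a double bond to nitrogen. Within the data shown here, no measured step makes this exact change, and the steps in hand give no firm direction. Any shift beyond the scatter could go either way, although none is the most likely outcome. The expected change is a 1.1-fold lower number from compound 3 to compound 4 (0.02 log units; within the scatter).

For compound 4 the estimated value is 12000 nM, with an expected range of 3500 nM to 45000 nM.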

Compound 4, half-maximal inhibitory concentration: 2250 nM
The estimate for compound 4 lay 5.3-fold (0.73 log units) above the measured number; the measured number lies below the stated range.
By their numbers in this assay, from the lowest: compound 4; then compounds 2 and 3 (each within the scatter of the next). At a limit, above all of these: compound 1.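

In this assay, the plain phenyl of compound 4 gives the lowest number of the series, shown by a 5.6-fold lower number from compound 3 to compound 4 (0.75 log units; beyond the scatter) and a 2.8-fold lower number from compound 2 to compound 4 (0.45 log units; beyond the scatter). The two dimethoxyphenyl groups looked alike when compared only with each other, but phenyl now shows that both stand higher than the ring with no added groups, and no compound shown goes against this. Compound 1 is a limit of the assay and not a number, so an at least 44-fold lower number from compound 1 to compound 4 (1.64 log units; beyond the scatter) gives only a minimum size for that change: the limit of > 100000 nM in this assay, at which 1 of the 4 values shown sits.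

Going by these compounds, it remains open whether a single methoxy or a single chlorine on the phenyl would already raise the number, or whether the pairs of groups are needed for that. An amine or a hydroxyl at this place could also shift the number in either direction, and the compounds shown give no guide to which.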